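Cyclopropyl for 3,4-dimethylphenyl on the amine nitrogen

The source may hold more compounds than are shown below. What is called first, only, known or untested is meant among the compounds shown, and "the series" means these compounds.

Measured so far in a functional assay on MCF7 cells (Homo sapiens) for inhibition, read by sulforhodamine B assay; on this read-out lower numbers stand for stronger inhibition and higher numbers for weaker inhibition:
- compound 1 `Cc1ccc(NC2=CC(=O)c3c(nc4n3[C@H]3OC[C@@H](O)[C@H]3OC4)C2=O)cc1C`: 4950 nM
- compound 2 `Cc1ccc(NC2=CC(=O)c3nc4n(c3C2=O)[C@H]2OC[C@@H](O)[C@H]2OC4)cc1C`: 2080 nM

Of these two numbers, compound 1 has the higher, meaning the weaker inhibition. The gap to compound 2 lies beyond the usual scatter of repeated measurements.

Next in line is compound 3 `O=C1C(NC2CC2)=CC(=O)c2c1nc1n2[C@H]2OC[C@@H](O)[C@H]2OC1`, not yet measured. Compared with compound 1, the change is cyclopropyl in place of 3,4-dimethylphenyl on an amine nitrogen. The same difference, cut one bond further out, reads (3,4-dimethylphenyl)amino to cyclopropylamino.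

Within the data shown here, no measured pair in this small set shows what such a change does, so the only anchor is compound 1 at 4950 nM. In this assay, no step beyond the scatter is expected, with a slight lean toward weaker inhibition. The estimated step is a 1.3-fold higher number from compound 1 to compound 3 (0.12 log units; within the scatter). Among the measured compounds shown here, the uncertainty is wide in both directions, as the data hold no example of this change. For compound 3 the expected value is 6500 nM, with an estimated range of 1800 nM to 22000 nM.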

Compound 3, half-maximal inhibitory concentration: > 16000 nM
Compound 3 ended at the assay's limit; the forecaster's own chance of this, stated with the estimate: 10%; at least 2.4-fold (0.39 log units) between middle value and limit.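

In this assay compound 3 reads > 16000 nM as a limit of the assay and not as a number. Cyclopropyl in place of 3,4-dimethylphenyl on the amine nitrogen gives an at least 3.2-fold higher number from compound 1 to compound 3 (0.50 log units; beyond the scatter) in this assay, so the group on this nitrogen does affect the read-out, which compounds 1 and 2 could not show, as both carry 3,4-dimethylphenyl there. From the compounds shown here alone, the step is a lower bound and its full size stays unknown because compound 3 ends at the limit: the limit of > 16000 nM in this assay, at which 1 of the 3 values shown sits.

Going by these compounds, it stays open whether the aromatic ring itself or only the larger size of the group counts at this nitrogen: a plain phenyl, a benzyl or a longer chain such as n-butyl in the same place would separate the two readings. Also open, on these data alone, is whether cyclopropyl in place of 3,4-dimethylphenyl on the core of compound 2 would give a step of similar size, or whether the step belongs to the core of compound 1 alone.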